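The source may report more compounds than this note shows. Statements on the series, on what has been measured and on what is new or still open speak of the compounds shown alone.

Compound 2 `O=C(Nc1ccnnc1)c1cc(N2C[C@H]3COC[C@H]3C2)ccc1OCc1ccccc1` shows the highest number of the three measured compounds in an assay on Sf9 cells for inhibition of Leucine-rich repeat serine/threonine-protein kinase 2 (Homo sapiens), read by TR-FRET, with stated times of 30 min and 2 h (a lower number here means a stronger inhibitor, a higher number a weaker inhibitor), where compound 2 gives 50.1 nM. Compound 1 `O=C(Nc1ccnnc1)c1cc(C(F)(F)F)ccc1OCc1ccccc1` gives 15.9 nM, and compound 3 `O=C(Nc1cccc(F)c1)c1cc(C(F)(F)F)ccc1OCc1ccc(F)cc1` gives 31.6 nM, a gap from compound 2 that stays within the usual scatter. Compound 4 `C[C@@H]1CN(c2ccc(OCc3ccccc3)c(C(=O)Nc3ccnnc3)c2)C[C@H](C)O1` differs from compound 2 in one place: a group of 8 heavy atoms (6 carbon, 1 nitrogen, 1 oxygen; one six-membered non-aromatic ring with 2 hetero atoms) in place of a group of 8 heavy atoms (6 carbon, 1 nitrogen, 1 oxygen; 2 five-membered non-aromatic rings with 1 hetero atom each), on an aromatic carbon. Going by the values given here, no measured step shows this exact exchange. Among the compounds with values here, the only step at the same place on the shared core is a 3.2-fold higher number from compound 1 to compound 2 (0.50 log units; beyond the scatter), which swapped a trifluoromethyl for the bicyclic amine. Since the entering and leaving groups are both saturated amine rings of matching size, a step of no more than the scatter is expected, a 1.0-fold lower number from compound 2 to compound 4 (0.00 log units; within the scatter). Compound 4 is therefore expected to give 50 nM, in a range of 20 nM to 130 nM.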

Compound 4, half-maximal inhibitory concentration: 20 nM
The estimate for compound 4 lay 2.5-fold (0.40 log units) above the measured number; measured number inside the range.
By their numbers in this assay, from the lowest: compounds 1, 4, 3 and 2 (each within the scatter of the next, the first and the last beyond it).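

In this assay, two saturated amine rings of the same heavy-atom count do not read alike at this position: the 2,6-dimethylmorpholin-4-yl group gives a 2.5-fold lower number from compound 2 to compound 4 (0.40 log units; beyond the scatter). The step from trifluoromethyl to an amine ring is also not always beyond the scatter, as a 1.3-fold higher number from compound 1 to compound 4 (0.10 log units; within the scatter) shows. No measurement offered here explains the difference between the two rings. Open, going by these compounds, is how a plain morpholin-4-yl or a piperidin-1-yl group would read here, which would separate the two methyl groups from the ring oxygen. On these data alone, the other stereoisomers of the dimethylmorpholine ring also remain open.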